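The source may hold more compounds than are shown below. What is called first, only, known or untested is meant among the compounds shown, and "the series" means these compounds.

Measured so far:
compound 1 `Nc1scc(CN2CCN(c3cc(Cl)cc(Cl)c3)CC2)c1C(=O)c1ccc(Cl)cc1` gives -74%
compound 2 `COc1ccc(N2CCN(Cc3csc(N)c3C(=O)c3ccc(Cl)cc3)CC2)cc1` gives -52%
compound 3 `Nc1scc(CN2CCN(c3c(F)cccc3F)CC2)c1C(=O)c1ccc(Cl)cc1` gives -80%

All three were tested in a functional assay on CHO cells with adenosine receptor A1 (Homo sapiens) as the target, read by cAMP accumulation and immunoassay, with a stated time of 6 min, tested at 10 uM; a lower number here means a stronger effect, a higher number a weaker effect of the compound at the concentration tested. Compound 3 holds the lowest of the three numbers; its nearest neighbour is compound 1, a step of a number 6 percentage points lower from compound 1 to compound 3 (within the scatter) that stays within the scatter, while compound 2 sits furthest away, the step of a number 28 percentage points lower from compound 2 to compound 3 (beyond the scatter) lying beyond it. The swap a number 22 percentage points higher from compound 1 to compound 2 (beyond the scatter) on the same ring nitrogen likewise moved the number beyond the scatter.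

Compound 4 `Nc1scc(CN2CCN(CCCc3ccc(Cl)cc3)CC2)c1C(=O)c1ccc(Cl)cc1` differs from compound 3 in one place: 3-(4-chlorophenyl)propyl in place of 2,6-difluorophenyl on an amine nitrogen in a ring. Among the compounds with values here, every measured step exchanged one aryl group for another on that ring nitrogen; none of them puts a 3-(4-chlorophenyl)propyl there, so no step bears directly on this change. A modest shift is expected, with the direction uncertain, and the account therefore places compound 4 at an estimated -55%, within a range from -85% to -20%, which is expected to mean a step of a number 25 percentage points higher from compound 3 to compound 4 (beyond the scatter).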

Compound 4, a percentage reported as activity, at one concentration (the size of the read-out at that concentration, not a potency): -76%
Beside the measured number, compound 4's estimate is 21 percentage points above it; the measured number falls inside the stated range.
By their numbers in this assay, from the lowest: compounds 3, 4 and 1 (each within the scatter of the next); then compound 2.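

In this assay, the amine nitrogen in the ring proves to tolerate more than an aryl group directly attached: replacing the aryl group with 3-(4-chlorophenyl)propyl gives a number 4 percentage points higher from compound 3 to compound 4 (within the scatter) and a number 2 percentage points lower from compound 1 to compound 4 (within the scatter), so the flexible chain leaves the number level with those of the two halogenated aryl compounds. Only the 4-methoxyphenyl compound stands apart, with a number 24 percentage points lower from compound 2 to compound 4 (beyond the scatter). Nothing measured here explains this result.

The compounds shown leave open whether the propyl chain or the 4-chlorophenyl group matters more for this reading, which a shorter chain or a plain phenyl in its place would address. They also leave open how far the position tolerates a carboxylic acid or a further amine on such a chain.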